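The source may report more compounds than this note shows. Statements on the series, on what has been measured and on what is new or still open speak of the compounds shown alone.

Measured so far:
Compound 1 `Nc1c(C(=O)c2ccccc2)sc(Nc2ccccc2)c1-c1nnc(NC(=O)c2ccccc2)o1`, in a functional assay on HepG2 cells (Homo sapiens) for cytotoxicity, read by MTT assay, with a stated time of 96 h (a lower number here means a stronger inhibitor, a higher number a weaker inhibitor), compound 1 gives 90.7 ug/mL.
Compound 2 `Nc1n[nH]c(Nc2ccccc2)c1-c1nnc(NC(=O)c2ccccc2)o1`, in this assay compound 2 gives 33.7 ug/mL.

Compound 2 stands lowest of the two numbers; compound 1 gives a higher number, and the gap between them is beyond the scatter. Compound 3 `Nc1nn(-c2ccccc2)c(Nc2ccccc2)c1-c1nnc(NC(=O)c2ccccc2)o1` differs from compound 2 by phenyl in place of hydrogen on an aromatic nitrogen. Among the measured compounds shown here, no step between measured compounds matches this change, so the account expects a step from compound 2 to compound 3 of a 1.2-fold higher number from compound 2 to compound 3 (0.07 log units; within the scatter), which is not clearly beyond the scatter. For compound 3 the estimated value in this assay is 40 ug/mL, between 12 ug/mL and 120 ug/mL.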

Compound 3, half-maximal inhibitory concentration: 98.7 ug/mL
Estimate against measurement, compound 3: 2.5-fold (0.39 log units) below; low and high end bracket the measured number.
By their numbers in this assay, from the lowest: compound 2; then compounds 1 and 3 (each within the scatter of the next).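

In this assay, among the compounds shown here, this is the first change in one place that can be read: phenyl in place of hydrogen on the aromatic nitrogen, next to the ring atom that bears an anilino group, gives a 2.9-fold higher number from compound 2 to compound 3 (0.47 log units; beyond the scatter) and so shows that this position is not indifferent to substitution. Nothing measured here accounts for the step. The compounds shown leave open whether methyl or a longer chain on this nitrogen would move the number as phenyl does.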